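The compounds below may be only part of what the source reports. "The series", "measured", "known", "first", "only" and "open" are said of these compounds alone.

Of the compounds shown here, three have been measured in a functional assay on DU-145 cells (Homo sapiens) for inhibition, read by trypan blue exclusion, with a stated time of 96 h; a lower number here means a stronger inhibitor of growth, a higher number a weaker inhibitor of growth. Compound 2 `CC(=O)c1ccc(/C=C(/Sc2ccc(C)cc2)C(=O)c2ccc(Br)cc2)cc1` gives 50000 nM, level with compound 3 `Cc1ccc(S/C(=C/c2ccc(-c3ccccc3)cc2)C(=O)c2ccc(Br)cc2)cc1` at 50000 nM; together these stand as the highest of the three numbers. Compound 1 `O=C(/C(=C\c1ccc([N+](=O)[O-])c(O)c1)SCc1ccc(Br)cc1)c1ccc(Br)cc1` gives 10000 nM, a lower number beyond the scatter. Compound 4 `Cc1ccc(S/C(=C/c2ccc(C)s2)C(=O)c2ccc(Br)cc2)cc1` is still unmeasured; it differs from compound 2 by 5-methylthiophen-2-yl in place of 4-acetylphenyl on a double-bonded chain carbon bound to a double-bonded chain carbon. Going by the values given here, the only measured step at this place, no change at the digits printed from compound 2 to compound 3 (within the scatter), left the number unchanged within the scatter. Among the compounds with values here, no measured step exchanges the ring itself, so that part of the change is untested. The expected step is therefore no change at the digits printed from compound 2 to compound 4 (within the scatter), none beyond the scatter. For compound 4 the estimate is 50000 nM, with a range from 20000 nM to 100000 nM.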

Compound 4, concentration for 50% growth inhibition: > 100000 nM
Compound 4 ended at the assay's limit (the forecaster's own chance of this, stated with the estimate: 25%); middle value at least 2.0-fold (0.30 log units) from the limit.
By their numbers in this assay, from the lowest: compound 1; then compounds 2 and 3 (each within the scatter of the next). At a limit, above all of these: compound 4.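

In this assay compound 4 gives > 100000 nM, which is a limit of the assay and not a number: the limit of > 100000 nM in this assay, at which 1 of the 4 values shown sits. Going by these compounds alone, this is the first measured change at this place that also exchanges the ring itself, and it reads an at least 2.0-fold higher number from compound 2 to compound 4 (0.30 log units; that floor lies within the scatter). Only a floor is therefore known, and the true size of the step stays unresolved.

Open, on these data alone, is whether the five-membered ring or its methyl group governs the read-out. Also open, as far as these compounds go, is how an amine or a carboxylic acid on the aromatic ring at this place would read.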